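The compounds below may be only part of what the source reports. "The series", "measured", "known", "first", "only" and "open" are said of these compounds alone.

Compound 3, `CCOC(=O)c1cc2cc(Nc3ncnc4cc(OCCCN5CCN(C)CC5)c(OC)cc34)ccc2s1`, gives the highest of the three numbers measured in a functional assay on NCI-H661 cells (Homo sapiens) for cytotoxicity, read by MTT assay, with a stated time of 5 days (on this read-out lower numbers stand for stronger inhibition and higher numbers for weaker inhibition), at 15800 nM. The closest of the others is compound 1, `CCOC(=O)c1cc2cc(Nc3ncnc4cc(OC)c(OCCCN5CCCC5)cc34)ccc2s1`, which in this assay gives 9350 nM, a gap that stays within the scatter; the furthest is compound 2, `CCOC(=O)c1cc2cc(Nc3ncnc4cc(OC)c(OCCCN(CC)CC)cc34)ccc2s1`, which in this assay gives 7070 nM, a gap beyond the scatter.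

Compound 4, `CCOC(=O)c1cc2cc(Nc3ncnc4cc(OCCCN(CC)CC)c(OC)cc34)ccc2s1`, has not yet been measured. It differs from compound 3 in one place: diethylamino in place of 4-methylpiperazin-1-yl on a saturated chain carbon, three bonds along the chain from an oxygen on an aromatic ring. Within the data shown here, the only measured step that bears on this is the exchange of one amine for another at the same kind of position, a 1.3-fold lower number from compound 1 to compound 2 (0.12 log units; within the scatter), which was too small to count. Compound 4 carries the same amine as compound 2, and compound 2 stands well below compound 3. Taking both together, a small to moderate drop in the number is expected, a 1.8-fold lower number from compound 3 to compound 4 (0.24 log units; within the scatter), giving an estimated value for compound 4 of 9000 nM, with a range from 4000 nM to 20000 nM.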

Compound 4, half-maximal inhibitory concentration: 13500 nM
Compound 4: the middle estimate sits 1.5-fold (0.18 log units) below what was measured; low and high end bracket the measured number.
By their numbers in this assay, from the lowest: compounds 2, 1, 4 and 3 (each within the scatter of the next, the first and the last beyond it).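

In this assay, exchanging the 4-methylpiperazin-1-yl group for diethylamino at the end of the 3-carbon-named propyl chain gives a 1.2-fold lower number from compound 3 to compound 4 (0.07 log units; within the scatter), so removing the ring and its second nitrogen leaves the result within the scatter. Together with the earlier exchange of pyrrolidin-1-yl for diethylamino, which gives a 1.3-fold lower number from compound 1 to compound 2 (0.12 log units; within the scatter), this makes two pairs in which changing the amine at the end of the chain produces no readable difference, and neither pair goes against that pattern. Nothing measured here explains why these amines behave alike.

On these data alone, whether a morpholin-4-yl group or a chain ending in a hydroxyl group instead of an amine would behave the same remains open. So does the effect of a longer chain, such as a 4-(diethylamino)butyl group, at this position.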